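This account rests on a few compounds, and the source may have more. Where it says the series, first, only, none or still open, it means among the compounds named here.

Compound 3 `COc1cc(=O)oc2cc(OCc3cccc(Br)c3)ccc12` stands at the top of the three numbers in an assay on isolated protein (strain Sprague-Dawley) for inhibition of Amine oxidase [flavin-containing] A (Rattus norvegicus), read by spectrophotometry, with a stated time of 5 min, tested at 10 uM (on this read-out higher numbers stand for more inhibition at the one concentration tested (going by the name of the read-out) and lower numbers for less inhibition), giving 27%, though compound 1 `CCOc1cc(=O)oc2cc(OCc3cccc(F)c3)ccc12`, which gives 25%, lies within the scatter of it. Compound 2 `CCOc1cc(=O)oc2cc(OCc3cccc(Cl)c3)ccc12` gives 2%. Among the compounds with values here, the only measured step, a number 23 percentage points lower from compound 1 to compound 2 (beyond the scatter), concerns the halogen on the aromatic ring and not the alkoxy group. Compound 4 `CCOc1cc(=O)oc2cc(OCc3cccc(Br)c3)ccc12` differs from compound 3 by methyl in place of hydrogen on a saturated chain carbon bound to an oxygen on an aromatic ring. Within the data shown here, no measured pair separates a methoxy from an ethoxy on this core, so that step offers no direct guide; compounds 1 and 2 already carry the ethoxy group and fall on both sides of compound 3. The step to compound 4 is therefore expected to be a number 2 percentage points lower from compound 3 to compound 4 (within the scatter), nothing beyond the scatter. Compound 4 is estimated at 25%, between 5% and 45%.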

Compound 4, a percentage reported as inhibition, at one concentration (the size of the read-out at that concentration, not a potency): 2.5%
The estimate for compound 4 lay 22.5 percentage points above the measured number; the whole stated range lies above it.
By their numbers in this assay, from the lowest: compounds 2 and 4 (each within the scatter of the next); then compounds 1 and 3 (each within the scatter of the next).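

In this assay, within the data shown here, the change from methoxy to ethoxy with bromo held fixed gives a number 24.5 percentage points lower from compound 3 to compound 4 (beyond the scatter) and is the first direct reading at this position, showing that one added methyl can matter. Among the ethoxy compounds, bromo in place of chloro gives a number 0.5 percentage points higher from compound 2 to compound 4 (within the scatter) and bromo in place of fluoro gives a number 22.5 percentage points lower from compound 1 to compound 4 (beyond the scatter) so fluoro is the one halogen that stands apart in this set.

Going by these compounds, what a propoxy group or an amine at this position would give stays open, as does whether the methoxy to ethoxy step holds with fluoro or chloro. No measurement here accounts for these steps.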